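The source may report more compounds than this note shows. Statements on the series, on what has been measured and on what is new or still open speak of the compounds shown alone.

Among the compounds with values here, compound 1, `O=C(Nc1cccc(Oc2nccc(C(F)(F)F)c2Cl)c1)C1CCCN(C(=O)c2cc(C(F)(F)F)cc(C(F)(F)F)c2)C1`, was tested in an ADME assay on PC-3 cells (Homo sapiens) for cytotoxicity, read by WST assay, tested at 100 uM (on this read-out higher numbers stand for more inhibition at the one concentration tested (going by the name of the read-out) and lower numbers for less inhibition), and at the single concentration used compound 1 gives 0%. Two simpler compounds sharing its core were run in the same way. Compound 2, `Cc1cccc(C(=O)N2CCCC(C(=O)Nc3ccc(Cl)cc3)C2)c1`, gives 0% in this assay, and compound 3, `N#Cc1cccc(C(=O)N2CCCC(C(=O)Nc3ccc(Cl)cc3)C2)c1`, gives 0%. Within the data shown here, the only measured step between neighbours, no change at the digits printed from compound 2 to compound 3 (within the scatter), covers a cyano in place of methyl on an aromatic carbon, and it left the read-out unchanged within the scatter. Compound 1 stands level with compound 2 and with compound 3 at the digits shown, so on these numbers nothing in this small set separates from the rest.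

Compound 4, `O=C(Nc1cccc(-c2cnco2)c1)C1CCCN(C(=O)c2cc(C(F)(F)F)cc(C(F)(F)F)c2)C1`, differs from compound 1 in one place: 1,3-oxazol-5-yl in place of (3-chloro-4-(trifluoromethyl)pyridin-2-yl)oxy on an aromatic carbon. Among the measured compounds shown here, no measured step matches this swap of one aromatic group for another on the same ring, so the step from compound 2 to compound 3 bears on it only loosely, as a sign that a change on an aromatic carbon of this core did not move the read-out. With every measured compound at the floor of the scale, compound 4 is expected to show no inhibition beyond the scatter, and the step of no change at the digits printed from compound 1 to compound 4 (within the scatter) is estimated to lie within it. Compound 4 is therefore estimated at 0% in this assay, within -10% to 10%.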

Compound 4, a percentage reported as inhibition, at one concentration (the size of the read-out at that concentration, not a potency): 9%
Estimate against measurement, compound 4: 9 percentage points below, and the stated range covers the measured number.
By their numbers in this assay, from the lowest: compounds 1, 2, 3 and 4 (each within the scatter of the next).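

Within the data shown here, at this position, on an aromatic carbon of a six-membered aromatic ring of carbon only and meta to a large group, the earlier compounds offered no comparison, and in this assay the exchange of (3-chloro-4-(trifluoromethyl)pyridin-2-yl)oxy for 1,3-oxazol-5-yl gives a number 9 percentage points higher from compound 1 to compound 4 (within the scatter). This shows that a single five-membered aromatic ring of 5 heavy atoms can replace a six-membered aromatic ring group of 12 heavy atoms, with its chlorine and fluorine atoms, without taking the read-out beyond the scatter, so this large change at this position has no effect that can be told apart from the scatter. Nothing available explains the small difference between the two compounds.

The compounds shown leave open whether a different kind of group at this position, such as an amine, a carboxylic acid or a longer alkyl chain, would move the read-out beyond the scatter. They also leave open whether any compound on this core would give a clear inhibition in this assay at the one concentration tested.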